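The source may hold more compounds than are shown below. What is called first, only, known or untested is meant among the compounds shown, and "the series" means these compounds.

Measured in an ADME assay on microsomes from liver (Rattus norvegicus) for metabolic stability, with a stated time of 10 min; on this read-out lower numbers stand for a less stable compound and higher numbers for a more stable compound:
compound 1 `COc1ccccc1-n1nc([C@H]2C[C@@H](C)O[C@@H](C)C2)cc1-c1ccc(Cl)cc1`: 18%
compound 2 `COCCCc1cc(-c2ccc(Cl)cc2)n(-c2ccccc2OC)n1`: 4%
compound 3 `COc1ccccc1-n1nc([C@@H]2CCO[C@H](C(C)C)C2)cc1-c1ccc(Cl)cc1`: 21%

The numbers place compound 3 level with the 2,6-dimethyloxan-4-yl analogue, with a number 3 percentage points higher from compound 1 to compound 3 (within the scatter). It stands apart from the 3-methoxypropyl analogue, with a number 17 percentage points higher from compound 2 to compound 3 (beyond the scatter).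

Compound 4 `COc1ccccc1-n1nc(C2=CC(C)(C)OC(C)(C)C2)cc1-c1ccc(Cl)cc1` has not yet been measured. Its structural change from compound 3 is a group of 10 heavy atoms (9 carbon, 1 oxygen; one six-membered non-aromatic ring with 1 hetero atom) in place of a group of 9 heavy atoms (8 carbon, 1 oxygen; one six-membered non-aromatic ring with 1 hetero atom), on an aromatic carbon. For the measured compounds named here, the entering group keeps a six-membered non-aromatic ring with 1 hetero atom, but it also has a double bond outside aromatic rings, a feature found in none of the measured compounds.

Going by the values given here, the closest precedent is the exchange of one such ring for another, with a number 3 percentage points higher from compound 1 to compound 3 (within the scatter). The exchange of a ring for a chain, with a number 14 percentage points lower from compound 1 to compound 2 (beyond the scatter), is a less direct guide, although it is the larger, modest step. The data therefore point to no step beyond the scatter in this assay, with a slight rise at most, although the double bond leaves the estimate uncertain. The expected step is a number 2 percentage points higher from compound 3 to compound 4 (within the scatter). For compound 4 the estimated value is 23%. The expected range for compound 4 runs from 8% to 42%.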

Compound 4, percent of the compound remaining: 37%
Estimate against measurement, compound 4: 14 percentage points below, and the stated range covers the measured number.
By their numbers in this assay, from the lowest: compound 2; then compounds 1 and 3 (each within the scatter of the next); then compound 4.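

In this assay, compound 4 shows that a ring-for-ring exchange on this aromatic carbon can shift the read-out beyond the scatter, with a number 16 percentage points higher from compound 3 to compound 4 (beyond the scatter) and a number 19 percentage points higher from compound 1 to compound 4 (beyond the scatter), whereas the earlier exchange between saturated rings gave only a number 3 percentage points higher from compound 1 to compound 3 (within the scatter). It also stands furthest from the open 3-methoxypropyl chain, with a number 33 percentage points higher from compound 2 to compound 4 (beyond the scatter), and its steps to all three other compounds make it the most stable of the four in this read-out. No measured information bears on why this entering group, the only one here with a double bond outside aromatic rings, gives the higher number.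

The entering group differs from the 2-isopropyloxan-4-yl group of compound 3 both in that double bond and in its arrangement of carbons, so these compounds cannot separate the contribution of the double bond from that of the substitution pattern, a question that the saturated 2,2,6,6-tetramethyloxan-4-yl group would address directly. As far as these compounds go, it also remains open whether the higher number would persist with a ring that carries nitrogen in place of oxygen, such as 1-methylpiperidin-4-yl, at this position.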